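Compound 3 to compound 4: chloro for trifluoromethyl

The source may report more compounds than this note shows. Statements on the series, on what has been measured and on what is new or still open speak of the compounds shown alone.

In a functional assay on MCF7 cells (Homo sapiens) for antiproliferative activity, read by MTT assay, with a stated time of 72 h (on this read-out higher numbers stand for weaker inhibition and lower numbers for stronger inhibition), compound 1 (`O=S(=O)(Oc1ccc(F)cc1)C1CC2OC1C(c1ccc(/C=C/c3cc(O)cc(O)c3)cc1)=C2c1ccc(O)cc1`) gives 13100 nM, compound 2 (`O=S(=O)(Oc1ccccc1C(F)(F)F)C1CC2OC1C(c1ccc(/C=C/c3cc(O)cc(O)c3)cc1)=C2c1ccc(O)cc1`) gives 18300 nM and compound 3 (`O=S(=O)(Oc1cccc(C(F)(F)F)c1)C1CC2OC1C(c1ccc(/C=C/c3cc(O)cc(O)c3)cc1)=C2c1ccc(O)cc1`) gives 11500 nM. Compound 3 therefore lies within the scatter of both other compounds. Compound 4 (`O=S(=O)(Oc1cccc(Cl)c1)C1CC2OC1C(c1ccc(/C=C/c3cc(O)cc(O)c3)cc1)=C2c1ccc(O)cc1`) differs from compound 3 in one group: chloro in place of trifluoromethyl on an aromatic carbon. The chloro takes the place of trifluoromethyl on an aromatic carbon, meta to a large group.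

Among the measured compounds shown here, no measured step makes this exact exchange. The closest evidence comes from the three changes to the aryl group on the oxygen: a 1.1-fold lower number from compound 1 to compound 3 (0.06 log units; within the scatter), a 1.4-fold higher number from compound 1 to compound 2 (0.15 log units; within the scatter) and a 1.6-fold lower number from compound 2 to compound 3 (0.20 log units; within the scatter). All three stay within the scatter, so no step beyond the scatter is expected in this assay, and no direction is favoured. The expected change is a 1.1-fold higher number from compound 3 to compound 4 (0.05 log units; within the scatter). For compound 4 the estimated value is 13000 nM, with an expected range of 7500 nM to 22000 nM.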

Compound 4, half-maximal inhibitory concentration: 12900 nM
The estimate for compound 4 lay 1.0-fold (0.00 log units) above the measured number; the measured number falls inside the stated range.
By their numbers in this assay, from the lowest: compounds 3, 4, 1 and 2 (each within the scatter of the next).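

In this assay, the exchange of trifluoromethyl for chloro on the aromatic carbon, with 4 heavy atoms leaving and 1 entering, stays within the scatter (a 1.1-fold higher number from compound 3 to compound 4 (0.05 log units; within the scatter)). Among the compounds shown here, this is the first direct reading at this position, and the 3-chlorophenyl group on the oxygen also stays within the scatter of the 2-(trifluoromethyl)phenyl group (a 1.4-fold lower number from compound 2 to compound 4 (0.15 log units; within the scatter)) and the 4-fluorophenyl group (a 1.0-fold lower number from compound 1 to compound 4 (0.01 log units; within the scatter)). No available evidence bears on why these numbers stay so close.

Going by these compounds, whether the numbers stay within the scatter with an amine or a carboxylic acid on this aromatic ring, or with a longer chain in place of the aryl group, remains open. On these data alone, all four compounds share one core, so the response to changes within that core also remains open.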